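The source may hold more compounds than are shown below. What is called first, only, known or untested is meant among the compounds shown, and "the series" means these compounds.

Measured so far in an assay on isolated protein for inhibition of Amine oxidase [flavin-containing] A (Homo sapiens), read by fluorescence and spectrophotometry, with a stated time of 20 min; on this read-out higher numbers stand for weaker inhibition and lower numbers for stronger inhibition:
compound 1 `O=C1/C(=C/c2ccccc2)Cc2cc(O)ccc21` — 1940 nM
compound 2 `Cc1cccc(/C=C2\Cc3cc(O)ccc3C2=O)c1` — 860 nM
compound 3 `N#Cc1ccc(/C=C2\Cc3cc(O)ccc3C2=O)cc1` — 2080 nM

Compound 2 stands lowest of the three numbers in this assay, and both of its gaps to the other compounds are beyond the scatter: a 2.3-fold lower number from compound 1 to compound 2 (0.35 log units; beyond the scatter), while compound 3 sits further off still. The unmeasured compound 4 `COc1cccc(/C=C2\Cc3cc(O)ccc3C2=O)c1` differs from compound 2 by methoxy in place of methyl on an aromatic carbon.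

Within the data shown here, two measured steps bear on this change, both substitutions on the same aromatic ring of the shared core: a 2.3-fold lower number from compound 1 to compound 2 (0.35 log units; beyond the scatter), a modest gain, and a 1.1-fold higher number from compound 1 to compound 3 (0.03 log units; within the scatter), no change beyond the scatter. Neither concerns methoxy itself, so the expected size rests on the observation that substituents at this ring move the number by at most a modest amount in either direction. Compound 4 is therefore expected to land near compound 2, with the step of a 1.2-fold higher number from compound 2 to compound 4 (0.07 log units; within the scatter) estimated to stay within the scatter. The estimate for compound 4 in this assay is 1000 nM, with a range from 400 nM to 2500 nM.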

Compound 4, half-maximal inhibitory concentration: 1190 nM
Beside the measured number, compound 4's estimate is 1.2-fold (0.08 log units) below it; measured number inside the range.
By their numbers in this assay, from the lowest: compounds 2, 4, 1 and 3 (each within the scatter of the next, the first and the last beyond it).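

In this assay methoxy on this aromatic carbon, meta to a large group, cannot be told apart from methyl (a 1.4-fold higher number from compound 2 to compound 4 (0.14 log units; within the scatter)). It cannot be told apart from hydrogen either (a 1.6-fold lower number from compound 1 to compound 4 (0.21 log units; within the scatter)), so compound 4 lies within the scatter of both compound 1 and compound 2, although those two are separated beyond it, and the hydrogen-bond acceptor that enters with methoxy brings no step beyond the scatter. No measurement available here accounts for these steps.

As far as these compounds go, whether an amine, a carboxylic acid or a longer chain at this place would move the number beyond the scatter remains open. Also open, from the compounds shown here alone, is whether methoxy on another carbon of this ring would give a similar number.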